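The compounds below may be only part of what the source reports. "The series", "measured", "known", "first", "only" and "open" are said of these compounds alone.

Compound 1 `CC(=O)SCCC(CCCCC(=O)O)SC(C)=O` and compound 3 `CC(=O)SCCC(CCCCC(=O)Nc1ccccc1)SC(C)=O` are built on one core, while compound 2 `O=C(O)CCCCC(CCSC(=O)c1ccccc1)SC(=O)c1ccccc1` and the still untested compound 4 `O=C(CCCCC(CCSC(=O)c1ccccc1)SC(=O)c1ccccc1)Nc1ccccc1` are built on another; the difference between the two cores is not broken down here.

In a functional assay on KB cells (Homo sapiens) for inhibition, read by MTT assay, with a stated time of 24 h, tested at 10 ug/mL (on this read-out higher numbers stand for more inhibition of growth at the one concentration tested and lower numbers for less inhibition of growth), compound 1 gives 8.88% and compound 3 gives 2.5%. The step of a number 6.4 percentage points lower from compound 1 to compound 3 (within the scatter) goes with the change (anilino in place of hydroxy on a carbonyl carbon). Compound 2 gives 2.68% in this assay.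

Compound 4 carries the same change relative to compound 2, namely (anilino in place of hydroxy on a carbonyl carbon). The step is expected to be a number 0.7 percentage points lower from compound 2 to compound 4 (within the scatter), resting on the measured step of a number 6.4 percentage points lower from compound 1 to compound 3 (within the scatter) and on the value of compound 2, 2.68%, which leaves little room to fall. Compound 4 is therefore expected to give about 2% in this assay, most likely between -6% and 9%.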

Compound 4, percent growth inhibition at one concentration: 2.67%
For compound 4 the middle estimate is 0.7 percentage points below the measured one, within the range that was stated.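

In this assay, anilino in place of hydroxy on a carbonyl carbon goes with a number 0 percentage points lower from compound 2 to compound 4 (within the scatter). Set beside the earlier step, the same change shows no difference between the two cores that can be told apart in this assay: the same change on two cores in this assay, a number 6.4 percentage points lower (within the scatter) from compound 1 to compound 3 and a number 0 percentage points lower (within the scatter) from compound 2 to compound 4, 6.4 percentage points apart, within the scatter of two such steps Neither step lies beyond the scatter, so the four compounds show neither that the change has an effect on either core nor that it has none, and they offer no measurable effect whose carrying over could be tested.

The compounds shown leave open how an aliphatic amine or a methyl ester in place of the hydroxy would read in this assay. They also leave open what a longer chain would do.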